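The compounds below may be only part of what the source reports. "The series", "measured", "known", "first", "only" and "open" are said of these compounds alone.

In an ADME assay on HEK293 cells (Homo sapiens) for cytotoxicity, read by MTT assay, with a stated time of 3 days (a lower number here means a stronger inhibitor, a higher number a weaker inhibitor), compound 1 `COc1ccc(-c2ccccc2)cc1` gives 17 ug/mL and compound 3 `COc1ccc(-c2ccccc2)c(OC)c1` gives 27 ug/mL. Methoxy in place of hydrogen on an aromatic carbon produces a 1.6-fold higher number from compound 1 to compound 3 (0.20 log units; within the scatter), so these two compounds stand level. Compound 2 `Nc1cccc(-c2ccc(O)cc2)c1`, which carries an amino group, is reported only as a limit, > 100 ug/mL. Compound 4 `COc1ccc(-c2cccc(N)c2)c(OC)c1` differs from compound 3 by amino in place of hydrogen on an aromatic carbon. Among the measured compounds shown here, no measured step covers this change, and the methoxy step cannot be carried over to a different group. For compound 2 the limit of > 100 ug/mL is the only hint, and it points towards a higher number. The expected change is a 1.7-fold higher number from compound 3 to compound 4 (0.22 log units; within the scatter). For compound 4 the estimated value is 45 ug/mL, with an expected range from 20 ug/mL to 100 ug/mL.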

Compound 4, half-maximal inhibitory concentration: 29.2 ug/mL
Compound 4: middle estimate off by 1.5-fold (0.19 log units), on the high side; low and high end bracket the measured number.
By their numbers in this assay, from the lowest: compounds 1, 3 and 4 (each within the scatter of the next). At a limit, above all of these: compound 2.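

Amino in place of hydrogen, on an aromatic carbon meta to a large group, gives a 1.1-fold higher number from compound 3 to compound 4 (0.03 log units; within the scatter) in this assay, so the two compounds stand level. Among the compounds shown here, this is the first single-place step for an amino group here, and it shows that this group at this place leaves the number of compound 3 unchanged within the scatter. Compound 2, which also carries an amino group, is reported only as a limit: the limit of > 100 ug/mL in this assay, at which 1 of the 4 values shown sits.

As far as these compounds go, whether a carboxylic acid or a longer chain at this place would also leave the number level stays open. What sets compound 2 apart cannot be read from these compounds.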